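The compounds below may be only part of what the source reports. "The series", "measured", "known", "first", "only" and "open" are said of these compounds alone.

In an ADME assay on Vero 76 cells (Chlorocebus sabaeus) for cytotoxicity, read by neutral red uptake, with a stated time of 3 days (on this read-out lower numbers stand for higher toxicity in this test and higher numbers for lower toxicity in this test), compound 1 (`Nc1ncnc2c1ncn2[C@@H]1C[C@H](CCO)[C@@H](O)[C@H]1O`) gives > 300000 nM, a limit of the assay and not a number. Compound 2 (`C[C@@H](O)C[C@H]1C[C@@H](n2cnc3c(N)ncnc32)[C@H](O)[C@@H]1O`) gives > 300000 nM, also a limit, so it has no exact value. Evidence from both compounds is the limit of > 300000 nM in this assay, at which 2 of the 2 values shown sit. Compound 3 (`C[C@H](O)C[C@H]1C[C@@H](n2cnc3c(N)ncnc32)[C@H](O)[C@@H]1O`) is related to compound 2 as follows: the two compounds have the same atoms and bonds and differ only in configuration as drawn: 1 of 5 stereo elements differ; a stereocentre at a saturated chain carbon is drawn R in compound 2 and S in compound 3. Going by the values given here, the only measured step is a step that the two limits leave unreadable from compound 1 to compound 2, so it offers no size to carry over, and no step beyond the scatter is expected in this assay. The expected change is a number no higher from compound 2 to compound 3 (the limit leaves the size open). Compound 3 is estimated at 300000 nM, with an expected range of 150000 nM to 600000 nM.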

Compound 3, half-maximal cytotoxic concentration: > 300000 nM
Compound 3: a limit, no number; the forecaster's own chance of this, stated with the estimate: 90%; the middle value sits exactly at the limit.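

No step can be read among compound 1, compound 2 and compound 3: each gives only a limit, not a number. The compounds shown leave open whether the added methyl or the configuration at the saturated chain carbon shifts the half-maximal cytotoxic concentration at all.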